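A few compounds are considered here, and "the series" means these few. Any claim that something is new, unique, unknown or untested is made for them only; others in the source may bear on it.

Measured compounds:
- compound 1 `COC(=O)c1ccc(NC2=CC(=O)c3ncncc3C2=O)cc1` gives 5800 nM in a functional assay on BXPC-3 cells (Homo sapiens) for cytotoxicity, read by MTT assay, with a stated time of 72 h; a lower number here means a stronger inhibitor, a higher number a weaker inhibitor
- compound 2 `O=C1C(Nc2ccc(-c3ccccc3)cc2)=CC(=O)c2ncncc21` gives 500 nM in this assay
- compound 3 `O=C1C(NCc2ccc(F)cc2)=CC(=O)c2ncncc21` gives 1400 nM in this assay

Compound 2 has the lowest number of the three in this assay, and its two steps to the others are both beyond the scatter, so on these numbers it is the strongest inhibitor. Compound 4 `O=C1C(Nc2ccc(CO)cc2)=CC(=O)c2ncncc21` differs from compound 2 in one place: hydroxymethyl in place of phenyl on an aromatic carbon. Among the compounds with values here, only one measured step bears on this change. Going from compound 1 to compound 2, where the phenyl replaced a methoxycarbonyl at the same position, the number fell sharply: a 12-fold lower number from compound 1 to compound 2 (1.06 log units; beyond the scatter). Removing the phenyl again and putting a small, two-heavy-atom hydroxymethyl in its place would undo that change in kind, though the hydroxymethyl is not the same group as the methoxycarbonyl, so a full return to the number of compound 1 is not assured. A step to a higher number, beyond the scatter, is therefore expected, with a 5.0-fold higher number from compound 2 to compound 4 (0.70 log units; beyond the scatter). Compound 4 is estimated at 2500 nM, in a range from 800 nM to 8000 nM.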

Compound 4, half-maximal inhibitory concentration: 5700 nM
Compound 4: the middle estimate sits 2.3-fold (0.36 log units) below what was measured, within the range that was stated.
By their numbers in this assay, from the lowest: compound 2; then compound 3; then compounds 4 and 1 (each within the scatter of the next).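

In this assay the change from phenyl to hydroxymethyl gives an 11-fold higher number from compound 2 to compound 4 (1.06 log units; beyond the scatter), so the advantage that came with the phenyl on this aromatic carbon does not survive with this small group. Hydroxymethyl and methoxycarbonyl are different groups, yet they cannot be told apart here, with a 1.0-fold lower number from compound 1 to compound 4 (0.01 log units; within the scatter), and among these three groups on this carbon only the phenyl stands out. Nothing measured here explains why the phenyl behaves differently from the other two groups.

From the compounds shown here alone, whether a different ring, such as a pyridyl or a saturated cyclohexyl, would keep the low number of compound 2 stays open. So does how an amine or a carboxylic acid on this carbon would compare with hydroxymethyl.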